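The compounds below may be only part of what the source reports. "The series", "measured", "known", "first", "only" and "open" are said of these compounds alone.

Compound 1 `O[C@H](c1ccccn1)[C@]1(c2cc(C(F)(F)F)ccn2)C[C@H](O)C1`: 270 nM
Compound 2 `C[C@]1(O)C[C@](c2cccc(C(F)(F)F)c2)([C@H](O)c2ccccn2)C1`: 1550 nM
Compound 3 `C[C@@]1(c2ccc(OC(F)(F)F)cc2)C[C@@](O)(c2ccccn2)CO1`: 1120 nM

Of the compounds shown here, three have been tested in an assay on HEK293 cells for antagonist activity at transient receptor potential cation channel subfamily V member 3 (Homo sapiens), read by FLIPR and calcium flux; on this read-out lower numbers stand for stronger inhibition and higher numbers for weaker inhibition. Compound 1 gives 270 nM, the lowest of the three numbers, and therefore the strongest inhibition measured here. Its nearest neighbour is compound 3 at 1120 nM, a gap that lies beyond the usual scatter of such measurements, and compound 2 at 1550 nM sits further away still, also beyond the scatter.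

Compound 4 `O[C@H](c1ccccn1)[C@]1(c2cc(C(F)(F)F)ccn2)C[C@@H](O)C1` has not yet been measured. Compared with compound 1, (the two compounds have the same atoms and bonds and differ only in configuration as drawn: 2 of 3 stereo elements differ; a stereocentre at a saturated ring carbon is drawn s in compound 1 and r in compound 4; a stereocentre at a saturated ring carbon is drawn R in compound 1 and S in compound 4). The two compounds therefore share every atom and bond and differ only in how two saturated ring carbons are arranged in space.

Going by the values given here, no measured pair in this set shows what such a change does, so the size of the step in this assay cannot be read from any neighbour. A change of configuration at two ring carbons can leave the number almost unchanged or shift it clearly in either direction; with no comparison to lean on, a moderate weakening is taken as the most likely outcome, and the step from compound 1 to compound 4 is expected to be a 2.2-fold higher number from compound 1 to compound 4 (0.35 log units; beyond the scatter). Compound 4 is accordingly estimated at 600 nM, with a plausible range from 150 nM to 2500 nM.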

Compound 4, antagonist equilibrium constant: 320 nM
Beside the measured number, compound 4's estimate is 1.9-fold (0.27 log units) above it, within the range that was stated.
By their numbers in this assay, from the lowest: compounds 1 and 4 (each within the scatter of the next); then compounds 3 and 2 (each within the scatter of the next).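

In this assay, the change of configuration at the two saturated ring carbons gives a 1.2-fold higher number from compound 1 to compound 4 (0.07 log units; within the scatter), so the read-out does not separate these two compounds. For this pair, then, how those two ring carbons are arranged in space makes no difference that this measurement can detect. Going by these compounds alone, this is the first comparison in the set that isolates a single kind of change, and it can be read directly because nothing else varies: the fact that compounds 1 and 4 differ only in the configuration as drawn.

From the compounds shown here alone, whether the same holds with another group on the shared core, such as an amine or a carboxylic acid in place of the hydroxyl group, remains open. Within the data shown here, compound 2 and compound 3 differ from compound 1 in more than one place, so no step to either can be read, and the contribution of the other parts of these molecules stays unknown.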